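The source may report more compounds than this note shows. Statements on the series, on what has been measured and on what is new or still open speak of the compounds shown alone.

Measured in an ADME assay on Caco-2 cells (Homo sapiens) for permeability; a lower number here means that the compound crosses the layer more slowly, a higher number that the compound crosses the layer faster:
- compound 1 `Cc1cn2cc(-c3cc4ccc(N5CCN(C)CC5)cc4c(=O)o3)nc2c(C)n1`: 1.2 10^-6 cm/s
- compound 2 `Cc1cn2nc(-c3cc(=O)n4cc(N5CCN(C)CC5)ccc4n3)cc2c(C)n1`: 7.5 10^-6 cm/s
- compound 3 `CCN1CCN(c2ccc3cc(-c4cn5cc(C)nc(C)c5n4)c(=O)oc3c2)C[C@@H]1C`: 1.2 10^-6 cm/s

Compound 2 stands highest of the three, and both other compounds lie below it by more than the scatter. Within the data shown here, compound 4 `Cc1cn2nc(-c3cc(=O)n4cc(N5CCNCC5)ccc4n3)cc2c(C)n1` has no measurement yet in this assay. It differs from compound 2 in one place: hydrogen in place of methyl on an amine nitrogen in a ring. In words, this is hydrogen in place of methyl on an amine nitrogen in a ring, 4-methylpiperazin-1-yl to piperazin-1-yl. Among the measured compounds shown here, no measured pair shows this change, so the expectation rests on the structural change alone. A downward move somewhat beyond the scatter is expected, an estimated 2.7-fold lower number from compound 2 to compound 4 (0.43 log units; beyond the scatter). For compound 4 the estimate is 2.8 10^-6 cm/s, with an expected range of 0.8 10^-6 cm/s to 7 10^-6 cm/s.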

Compound 4, apparent permeability: 14 10^-6 cm/s
Compound 4: middle estimate off by 5.0-fold (0.70 log units), on the low side; measured number above the stated range.
By their numbers in this assay, from the lowest: compounds 1 and 3 (each within the scatter of the next); then compounds 2 and 4 (each within the scatter of the next).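

In this assay, hydrogen in place of methyl on an amine nitrogen in a ring gives a 1.9-fold higher number from compound 2 to compound 4 (0.27 log units; within the scatter). At this position, 4-methylpiperazin-1-yl and piperazin-1-yl therefore cannot be told apart in this read-out, so the methyl group is not required to keep the number of compound 2. Nothing at hand explains this result.

Open, going by these compounds, is whether an acetyl group or a longer chain such as propyl on this nitrogen would also stay within the scatter. Also open, on these data alone, is whether the same change would read alike on the core of compound 1.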